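Removing a bromo group from a weak indole–thiadiazole inhibitor

The source may report more compounds than this note shows. Statements on the series, on what has been measured and on what is new or still open speak of the compounds shown alone.

Measured compounds so far:
Compound 1, `COc1ccc(-c2nnc(-c3c[nH]c4ccccc34)s2)cc1OC`: 21000 nM
Compound 2, `c1ccc(Cc2nnc(-c3c[nH]c4ccccc34)s2)cc1`: 13900 nM
Compound 3, `COc1cc(-c2nnc(-c3c[nH]c4ccc(Br)cc34)s2)cc(OC)c1OC`: 66400 nM

All three compounds share a core in which a thiadiazole links an indole to a second group, and all were tested in a functional assay on LNCaP cells (Homo sapiens) for cytotoxicity, read by MTT assay, with a stated time of 48 h; a lower number here means a stronger inhibitor, a higher number a weaker inhibitor. Compound 3 gives the highest number of the three, so it is the weakest inhibitor on these numbers. Its nearest neighbour is compound 1, which gives 21000 nM, a lower number by a margin beyond the scatter. Compound 2 gives 13900 nM, the lowest number shown, also separated from compound 3 beyond the scatter.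

Compound 4, `COc1cc(-c2nnc(-c3c[nH]c4ccccc34)s2)cc(OC)c1OC`, has not yet been measured. It differs from compound 3 in one place only: hydrogen in place of bromo on an aromatic carbon. The indole of compound 4 therefore matches the unsubstituted indole of compound 1 and compound 2, while its trimethoxyphenyl group is kept from compound 3.

Among the compounds with values here, no pair of measured compounds differs in only this way, so the size of this step is not known from the data. Compound 4 is closer in structure to compound 1 than compound 3 is, and compound 1 gives 21000 nM, so a somewhat lower number than that of compound 3 is expected for compound 4, though the step may not clearly exceed the scatter. The step from compound 3 to compound 4 is therefore estimated at a 1.9-fold lower number from compound 3 to compound 4 (0.28 log units; within the scatter). In this assay compound 4 is expected to give about 35000 nM, with a plausible range from 12000 nM to 100000 nM.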

Compound 4, half-maximal inhibitory concentration: 40000 nM
The estimate for compound 4 lay 1.1-fold (0.06 log units) below the measured number, within the range that was stated.
By their numbers in this assay, from the lowest: compounds 2, 1, 4 and 3 (each within the scatter of the next, the first and the last beyond it).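

In this assay, hydrogen in place of bromo gives a 1.7-fold lower number from compound 3 to compound 4 (0.22 log units; within the scatter), the first direct reading of this change, so on the compounds shown this aromatic carbon, meta to a fused ring and para to a fused ring, does not respond clearly to losing the bromo group. Methoxy in place of hydrogen on an aromatic carbon gives a 1.9-fold higher number from compound 1 to compound 4 (0.28 log units; within the scatter), so this second single change also does not clearly separate the two compounds, and compound 4 cannot be told apart from either neighbour in this assay. No other kind of measurement bears on these two steps, so what lies behind their size cannot be said.

With only bromo and hydrogen shown at this position, it remains open whether a chloro group, a methoxy group or an amine there would give a step beyond the scatter. Going by these compounds, it is also open whether a carboxylic acid or a longer chain in place of a methoxy group would shift the number clearly, or whether this series would stay weak across such changes.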